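A few compounds are considered here, and "the series" means these few. Any claim that something is new, unique, unknown or untested is made for them only; others in the source may bear on it.

Measured compounds:
- compound 1, `COc1cc(NC(=O)Nc2ccccc2)cc(OC)c1OC`: "not determined" (no result reported)
- compound 2, `COc1cc(NC(=O)Nc2cccc([N+](=O)[O-])c2)cc(OC)c1OC`: 82500 nM

Compound 1 carries a plain phenyl ring on one side of its urea. In a functional assay on Daoy cells (Homo sapiens) for cytotoxicity, read by MTT assay, with a stated time of 72 h (on this read-out higher numbers stand for weaker inhibition and lower numbers for stronger inhibition), compound 1 is recorded as "not determined" (no result reported), so no number exists for it and it stands nowhere on the scale. Among the compounds with values here, compound 2, its nitro-bearing relative, is the only compound with a figure: in this assay compound 2 gives 82500 nM, a weak result. Within the data shown here, no step between measured compounds can be counted, and nothing in the pair tells how the phenyl ring itself compares to the nitrophenyl one.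

Compound 3, `COc1cc(NC(=O)Nc2ccc(F)cc2)cc(OC)c1OC`, is reached from compound 1 by fluoro in place of hydrogen on an aromatic carbon. With no measured starting point, the size of this step in this assay can only be guessed; a small shift, or none beyond the scatter, seems most likely in either direction, and the one figure available, from compound 2, sits in the weak range. Compound 3 is therefore expected to give about 70000 nM in this assay, within a range from 20000 nM to 250000 nM.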

Compound 3, half-maximal inhibitory concentration: 104000 nM
The estimate for compound 3 lay 1.5-fold (0.17 log units) below the measured number, within the range that was stated.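

Compound 3 gives 104000 nM while compound 1 is recorded as "not determined" (no result reported) and has no number, so no step can be read between these two compounds. As far as these compounds go, how far the change from phenyl to 4-fluorophenyl moves the cytotoxic result remains open. No further data shown here bear on this result.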